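This account rests on a few compounds, and the source may have more. Where it says the series, first, only, none or still open, it means among the compounds named here.

Compound 1, `CCn1c(NC(C)C)nc2c(C3CCN(c4ccccn4)CC3)csc2c1=O`, in an assay on cells for inhibition of high affinity 3',5'-cyclic-AMP phosphodiesterase 7A (Homo sapiens), read by scintillation counting and cAMP accumulation, with a stated time of 30 min (a lower number here means a stronger inhibitor, a higher number a weaker inhibitor), gives 6.8 nM.
Compound 2, `CCn1c(NC2CC2)nc2ccsc2c1=O`, gives 2600 nM.
Compound 3, `CCn1c(NC(C)C)nc2c(-c3cncnc3)csc2c1=O`, gives 7.6 nM.

Compound 2 gives the highest number of the three and is therefore the weakest inhibitor here. Compounds 1 and 3 each carry both a different amine and an added group on the shared core, so the two changes cannot be pulled apart from these numbers alone. Compound 4, `CCn1c(NC2CCC2)nc2ccsc2c1=O`, keeps everything of compound 2 except one group: cyclobutyl in place of cyclopropyl on a nitrogen on an aromatic ring. Among the compounds with values here, no measured pair shows this single swap, so its effect in this assay is uncertain; the expected step of a 1.4-fold lower number from compound 2 to compound 4 (0.16 log units; within the scatter) is small and may well stay within the scatter. Compound 4 is therefore expected to give about 1800 nM, with a range from 500 nM to 6000 nM.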

Compound 4, half-maximal inhibitory concentration in the high affinity 3',5'-cyclic-AMP phosphodiesterase 7A assay: 300 nM
Estimate against measurement, compound 4: 6.0-fold (0.78 log units) above; the measured number lies below the stated range.
By their numbers in the high affinity 3',5'-cyclic-AMP phosphodiesterase 7A assay, from the lowest: compounds 1 and 3 (each within the scatter of the next); then compound 4; then compound 2.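

In the high affinity 3',5'-cyclic-AMP phosphodiesterase 7A assay, cyclobutyl in place of cyclopropyl on a nitrogen on an aromatic ring, with nothing else changed, gives an 8.7-fold lower number from compound 2 to compound 4 (0.94 log units; beyond the scatter). The group at this place therefore matters on its own, which compounds 1 and 3, each differing from compound 2 in more than one place, could not show. In a physicochemical assay for solubility, in phosphate buffer, at pH 6.8 (a higher number here means a more soluble compound, a lower number a less soluble compound), compound 2 gives 430 ug/mL and compound 4 gives 6.3 ug/mL. The same swap comes at a cost in the physicochemical assay: the measured solubility of compound 2, 430 ug/mL, and of compound 4, 6.3 ug/mL, a 68-fold lower number (1.83 log units; beyond the scatter)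

Going by these compounds, whether cyclopentyl on this nitrogen would lower the number further in the high affinity 3',5'-cyclic-AMP phosphodiesterase 7A assay remains open. So does whether this swap would have a step of similar size on the core of compound 1 or compound 3.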